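Three methyl groups added to a weak growth inhibitor

The source may hold more compounds than are shown below. What is called first, only, known or untested is meant among the compounds shown, and "the series" means these compounds.

Measured so far:
Compound 2, `CN1CCN(c2ccc(Nc3ncc(Cl)c(Nc4ccccc4)n3)nc2)CC1`: 51800 nM
Compound 1, `Cc1ccccc1Nc1nc(Nc2ccc(N3CCCCC3)cc2)ncc1Cl`: > 100000 nM

Both compounds were tested in a functional assay on MCF7 cells (Homo sapiens) for inhibition, read by CCK-8 assay, with a stated time of 48 h; on this read-out higher numbers stand for weaker inhibition of growth and lower numbers for stronger inhibition of growth. Compound 2 is the only one of the two that gives a number in this assay, and that number, 51800 nM, marks it as a weak inhibitor of growth. For compound 1 the assay reports only a limit, > 100000 nM, rather than a number (the limit of > 100000 nM in this assay, at which 1 of the 2 values shown sits). Compound 1 also carries a methyl on the ring attached to the same kind of nitrogen.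

Compound 3, `Cc1cc(C)c(Nc2nc(Nc3ccc(N4CCN(C)CC4)cn3)ncc2Cl)c(C)c1`, has not yet been measured. It differs from compound 2 in one place: 2,4,6-trimethylphenyl in place of phenyl on a nitrogen on an aromatic ring. Going by the values given here, no step between two measured compounds is available to calibrate this change, so the expectation rests on compound 2 alone and on the limit seen for compound 1. The expected step of a 1.4-fold higher number from compound 2 to compound 3 (0.16 log units; within the scatter) is a modest weakening, possibly not beyond the usual scatter, with a real chance that only a limit is reported. Compound 3 is therefore estimated at 75000 nM, within a range from 25000 nM to 200000 nM.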

Compound 3, concentration for 50% growth inhibition: 9470 nM
Compound 3: the middle estimate sits 7.9-fold (0.90 log units) above what was measured, and the stated range ends above it.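

In this assay, replacing phenyl with 2,4,6-trimethylphenyl on the nitrogen gives a 5.5-fold lower number from compound 2 to compound 3 (0.74 log units; beyond the scatter). Going by these compounds alone, the step is beyond the usual scatter and is the first one that can be read at this position, showing that the added methyl groups go with stronger inhibition of growth rather than a loss of it. Nothing measured for these compounds shows why the number fell, so the step records an effect without explaining it.

The compounds shown leave open whether all three methyl groups contribute to the step or whether one of them alone accounts for it. They also leave open whether ethyl groups, methoxy groups or a carboxylic acid on the same ring would move the number in the same direction, in the opposite direction or not at all.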